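Swapping Ethynyl for Vinyl on Compound 2

The compounds below may be only part of what the source reports. "The series", "measured", "known", "first", "only" and "open" are said of these compounds alone.

Within the data shown here, only two compounds have numbers so far, both measured in a functional assay on T98G cells (Homo sapiens) for inhibition, read by colorimetric assay and MTT assay, with a stated time of 72 h; a higher number here means a weaker inhibitor, a lower number a stronger inhibitor. Compound 1 (`Cn1c2cnc1OCCCCCCCCOc1ccc(F)cc1-2`) gives 77000 nM. Compound 2 (`C#CCCCCOc1ncc(-c2ccccc2OC)n1C`) gives 35000 nM, the lower of the two numbers, and so it is the stronger inhibitor of the pair by a gap that lies beyond the usual scatter.

The next compound to be tested is compound 3 (`C=CCCCCOc1ncc(-c2ccccc2OC)n1C`), which is made from compound 2 by one small edit: vinyl in place of ethynyl on a saturated chain carbon, four bonds along the chain from an oxygen on an aromatic ring. Neither measured compound shows what this kind of edit does, so the expectation rests on the structural change alone, and that change is small. No shift beyond the scatter is expected in this assay. The expected change is a 1.1-fold higher number from compound 2 to compound 3 (0.06 log units; within the scatter), which would be too small to separate the two compounds. For compound 3 the estimated value is 40000 nM, with an expected range from 17000 nM to 85000 nM.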

Compound 3, half-maximal inhibitory concentration: 5000 nM
Estimate against measurement, compound 3: 8.0-fold (0.90 log units) above; the measured number lies below the stated range.
By their numbers in this assay, from the lowest: compound 3; then compound 2; then compound 1.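

This position is sensitive to a small edit: in this assay, vinyl in place of ethynyl gives a 7.0-fold lower number from compound 2 to compound 3 (0.85 log units; beyond the scatter), even though both groups hold two carbons and the only counted difference is a double bond for a triple bond. Among these compounds, the earlier compounds formed no pair differing in one place, so this is the first sign that the number responds to the group on a saturated chain carbon, four bonds along the chain from an oxygen on an aromatic ring. Nothing available explains why the vinyl compound gives the lower number, and no supporting data bear on this step.

The compounds shown leave open whether the double bond itself matters, since an ethyl group in the same place, with no multiple bond at all, would test that directly. Also open, on these data alone, is whether a longer chain carrying the same vinyl group would keep the lower number, and whether the same swap would give a step of similar size on the core of compound 1.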